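A Nitrophenyl Shift on Compound 1

The source may report more compounds than this note shows. Statements on the series, on what has been measured and on what is new or still open speak of the compounds shown alone.

Measured so far in a functional assay on HepG2 cells (Homo sapiens) for cytotoxicity, read by MTT assay, with a stated time of 72 h; on this read-out higher numbers stand for weaker inhibition and lower numbers for stronger inhibition:
- compound 1 `CNC(=O)c1cc(Oc2ccc(C(=O)/C=C/c3ccc([N+](=O)[O-])cc3)cc2)ccn1`: "not determined" (no result reported)
- compound 2 `CNC(=O)c1cc(Oc2ccc(/C=C/C(=O)c3ccc([N+](=O)[O-])cc3)cc2)ccn1`: 41400 nM

Compound 1 has no place on the numerical scale, since its entry in this assay reads "not determined" (no result reported) and gives no single number. The only figure available from the two measured compounds is therefore that of compound 2, at 41400 nM.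

The next compound, compound 3 `CNC(=O)c1cc(Oc2ccc(C(=O)/C=C/c3cccc([N+](=O)[O-])c3)cc2)ccn1`, keeps the core of compound 1 and has the same atoms, joined differently. It carries 3-nitrophenyl in place of 4-nitrophenyl on a double-bonded chain carbon bound to a double-bonded chain carbon.

Within the data shown here, no measured step bears on this change, and without a number for compound 1 no step from it can be calculated. The expectation in this assay is for no step beyond the usual scatter in either direction, which would leave compound 3 in the same range as compound 2 at 41400 nM. This rests on a single number, so the expectation is loose.

Compound 3 is expected at about 35000 nM, with an estimated range of 12000 nM to 100000 nM.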

Compound 3, half-maximal inhibitory concentration: > 50000 nM
Compound 3: only a limit was reported; the forecaster's own chance of this, stated with the estimate: 25%; at least 1.4-fold (0.15 log units) between middle value and limit.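

In this assay compound 3 gives > 50000 nM, which is a limit and not a number. Compound 1 has no number there, and no step can be read between compound 1 and compound 3. The compounds shown leave open whether exchanging 4-nitrophenyl for 3-nitrophenyl shifts the result in this assay at all, and in which direction.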